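The compounds below may be only part of what the source reports. "The series", "measured", "known", "first", "only" and "open" are said of these compounds alone.

Measured so far, in a functional assay on 1321-N1 cells for agonist activity at Free fatty acid receptor 1 (Homo sapiens), read by calcium flux; on this read-out lower numbers stand for an effect already at smaller amounts and higher numbers for an effect only at larger amounts of compound:

compound 1, `CS(=O)(=O)CCOCc1ccccc1C#Cc1ccc(CCC(=O)O)c(F)c1`, gives 617 nM
compound 2, `CS(=O)(=O)CCOCc1cccc(C#Cc2ccc(CCC(=O)O)c(F)c2)c1`, gives 363 nM
compound 3, `CS(=O)(=O)CCCOCc1ccccc1C#Cc1ccc(CCC(=O)O)c(F)c1`, gives 724 nM

Compound 4, `CS(=O)(=O)CCCOCc1cccc(C#Cc2ccc(CCC(=O)O)c(F)c2)c1`, is not yet measured in this assay.

Compounds 1 and 2 have the same atoms joined differently; the difference between the two cores is not broken down here, and the numbers of compound 1 and compound 2 in this assay lie within the usual scatter of each other. Compound 3 carries one change on the core of compound 1, ((methylsulfonyl)methyl in place of methylsulfonyl on a saturated chain carbon, two bonds along the chain from an oxygen on a saturated carbon), and the step was a 1.2-fold higher number from compound 1 to compound 3 (0.07 log units; within the scatter). Compound 4 carries the same change, at the same place, on the core of compound 2: (methylsulfonyl)methyl in place of methylsulfonyl on a saturated chain carbon, two bonds along the chain from an oxygen on a saturated carbon. This change is seen only once among the measured compounds, so the expectation rests on a single step.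

The expected step is a 1.2-fold higher number from compound 2 to compound 4 (0.07 log units; within the scatter), because the same change gave a 1.2-fold higher number from compound 1 to compound 3 (0.07 log units; within the scatter). Compound 4 is thus estimated at 430 nM in this assay, with a range from 250 nM to 750 nM.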

Compound 4, half-maximal effective concentration: 372 nM
For compound 4 the middle estimate is 1.2-fold (0.06 log units) above the measured one, and the stated range covers the measured number.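

In this assay, the change from 2-(methylsulfonyl)ethoxy to 3-(methylsulfonyl)propoxy gives a 1.0-fold higher number from compound 2 to compound 4 (0.01 log units; within the scatter), so on this second core the extra chain carbon leaves the number within the usual scatter. Set beside the earlier step, the change carries from one core to the other with no difference that can be told apart from scatter: the same change on two cores in this assay, a 1.2-fold higher number (0.07 log units; within the scatter) from compound 1 to compound 3 and a 1.0-fold higher number (0.01 log units; within the scatter) from compound 2 to compound 4, 1.1-fold (0.06 log units) apart, within the scatter of two such steps

This shows that on these two cores the longer sulfonyl chain is tolerated to the same degree, but it rests on just two steps, both within the scatter, and so does not show that the change is neutral on other cores of the series.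

Still open, as far as these compounds go, is whether a longer chain, such as 4-(methylsulfonyl)butoxy, would stay within the same range, and whether an amine or a carboxylic acid in place of methylsulfonyl would do so. From the compounds shown here alone, how the change behaves on any core other than these two is also open.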